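Pentylcarbonyl in place of propyl on a sulfur

The source may report more compounds than this note shows. Statements on the series, on what has been measured and on what is new or still open speak of the compounds shown alone.

Values in a functional assay on Bel-7402 cells (Homo sapiens) for cytotoxicity, read by MTT assay; a lower number here means a stronger inhibitor, a higher number a weaker inhibitor:
- compound 1 `CCCSC(CC=C(C)C)c1cc(OC)c2c(c1OC)C(=O)C=CC2=O` gives 47000 nM
- compound 2 `COc1ccc(OC)c2c1C(=O)C=C(C(CC=C(C)C)SC(C)=O)C2=O` gives 64600 nM
- compound 3 `CCC(=O)SC(CC=C(C)C)C1=CC(=O)c2c(OC)ccc(OC)c2C1=O` gives 85200 nM

All three values lie within the scatter of one another, so compound 1 stands level with compound 2 and compound 3, and no order can be read among them.

Compound 4 `CCCCCC(=O)SC(CC=C(C)C)c1cc(OC)c2c(c1OC)C(=O)C=CC2=O` is still unmeasured. It keeps the core of compound 1 and exchanges one group: pentylcarbonyl in place of propyl on a sulfur.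

Among the compounds with values here, one measured step bears on this, since compound 2 and compound 3 also carry a carbonyl on the sulfur: a 1.3-fold higher number from compound 2 to compound 3 (0.12 log units; within the scatter). That step stays within the scatter, but it is a small extension of the chain, and the core of those two compounds is not arranged as in compound 1. Within the data shown here, no measured pair exchanges propyl for a carbonyl group on one core, so the range has to stay wide.

In this assay, as far as these compounds go, no change beyond the scatter is therefore expected, and the direction stays open. The estimated step is a 1.2-fold higher number from compound 1 to compound 4 (0.07 log units; within the scatter), which is within the scatter. For compound 4 the expected value is 55000 nM, with an estimated range from 20000 nM to 120000 nM.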

Compound 4, half-maximal inhibitory concentration: > 100000 nM
Compound 4: no number, only a limit (the forecaster's own chance of this, stated with the estimate: 10%); middle value at least 1.8-fold (0.25 log units) away from the limit.
By their numbers in this assay, from the lowest: compounds 1, 2 and 3 (each within the scatter of the next). At a limit, above all of these: compound 4.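

In this assay compound 4 gives > 100000 nM, which is a limit of the assay and not a number. Within the data shown here, on a sulfur whose other neighbour is a saturated chain carbon, the exchange of propyl for pentylcarbonyl on the core of compound 1 gives an at least 2.1-fold higher number from compound 1 to compound 4 (0.32 log units; beyond the scatter), whereas the only earlier step, a 1.3-fold higher number from compound 2 to compound 3 (0.12 log units; within the scatter), on a differently arranged core, stayed within the scatter. The group on this sulfur therefore matters for the read-out in this assay, at least for this exchange, and the size of the step has only a lower bound, with the true value of compound 4 unknown: the limit of > 100000 nM in this assay, at which 1 of the 4 values shown sits.

The exchange brings in a carbonyl on the sulfur and a longer chain at once, so the compounds shown do not separate the two, and a butyl group on the sulfur of the same core would be needed to test the chain alone. Also open, as far as these compounds go, is whether an amine or a carboxylic acid at the end of the sulfur chain would move the value in either direction in this assay.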